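The source may hold more compounds than are shown below. What is called first, only, known or untested is meant among the compounds shown, and "the series" means these compounds.

In a functional assay on CCRF-CEM cells (Homo sapiens) for inhibition, with a stated time of 72 h (on this read-out lower numbers stand for stronger inhibition and higher numbers for weaker inhibition), compound 1 (`CCC(C)N(C(=O)[C@H](CC(=O)OC)NC(=O)OC(C)(C)C)C1(C(=O)NCc2ccccc2)CCN(Cc2ccccc2)CC1`) gives 19000 nM and compound 2 (`CCC(C)N(C(=O)[C@H](CC(=O)OC)NC(=O)OCc1ccccc1)C1(C(=O)NCc2ccccc2)CCN(Cc2ccccc2)CC1`) gives 4500 nM. Compound 3 (`COC(=O)C[C@H](N)C(=O)N(Cc1ccccc1)C1(C(=O)NCc2ccccc2)CCN(Cc2ccccc2)CC1`) gives 104000 nM, the highest of the three numbers. Compound 4 (`CCC(C)N(C(=O)[C@@H](N)CC(=O)OC)C1(C(=O)NCc2ccccc2)CCN(Cc2ccccc2)CC1`) changes compound 3 in one place: sec-butyl in place of benzyl on an amide-type nitrogen. Within the data shown here, the only measured single-place step, a 4.2-fold lower number from compound 1 to compound 2 (0.63 log units; beyond the scatter), concerns a different place. Compound 1 and compound 2 carry sec-butyl on this nitrogen, but they also differ from compound 4 elsewhere, so they do not isolate the change. No step beyond the scatter is therefore expected in this assay, in either direction, and the uncertainty is wide. The estimated step is a 1.3-fold lower number from compound 3 to compound 4 (0.11 log units; within the scatter). The estimate for compound 4 is 80000 nM, with an expected range of 30000 nM to 200000 nM.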

Compound 4, half-maximal inhibitory concentration: 238000 nM
Estimate against measurement, compound 4: 3.0-fold (0.47 log units) below; measured number outside the range, above it.
By their numbers in this assay, from the lowest: compound 2; then compound 1; then compound 3; then compound 4.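

On the amide-type nitrogen, sec-butyl does not match benzyl when the amine nitrogen carries hydrogen in this assay (a 2.3-fold higher number from compound 3 to compound 4 (0.36 log units; beyond the scatter)), so this position is sensitive to the change. With sec-butyl held constant, the amine nitrogen carries far more weight: removing benzyloxycarbonyl gives (a 53-fold higher number from compound 2 to compound 4 (1.72 log units; beyond the scatter)) and removing tert-butoxycarbonyl gives (a 13-fold higher number from compound 1 to compound 4 (1.10 log units; beyond the scatter)). Nothing measured here explains either effect.

Still open, on these data alone, is whether benzyl on the amide-type nitrogen would also beat sec-butyl with benzyloxycarbonyl on the amine nitrogen. Cyclohexyl or a longer chain such as n-hexyl at this position also remains untested here.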